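Quinolin-4-yl Amide Tested in Rat Blood

A few compounds are considered here, and "the series" means these few. Any claim that something is new, unique, unknown or untested is made for them only; others in the source may bear on it.

Of the compounds shown here, three sharing one core have been measured in a functional assay on the whole organism (blood) with Rattus norvegicus as the target, with stated times of 24 h and 1 h, at a dose of 5 mg/kg by the intraperitoneal route; a higher number here means a stronger effect of the compound at the dose given, a lower number a weaker effect. Compound 1 `O=C(NC1CCCCC1)NS(=O)(=O)N1CCC(CCNC(=O)c2cscn2)CC1` gives 23%, compound 2 `COc1ncccc1C(=O)NCCC1CCN(S(=O)(=O)NC(=O)NC2CCCCC2)CC1` gives 33%, and compound 3 `Cc1ncccc1C(=O)NCCC1CCN(S(=O)(=O)NC(=O)NC2CCCCC2)CC1` gives 16%. Compound 3 stands at the low end: a number 7 percentage points lower from compound 1 to compound 3 (within the scatter), whereas a number 17 percentage points lower from compound 2 to compound 3 (beyond the scatter). One aryl swap at the carbonyl carbon gave a number 10 percentage points higher from compound 1 to compound 2 (within the scatter). The other aryl swap, already noted, was likewise small.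

Compound 4 `O=C(NC1CCCCC1)NS(=O)(=O)N1CCC(CCNC(=O)c2ccnc3ccccc23)CC1` has not yet been measured. It differs from compound 3 in one place: quinolin-4-yl in place of 2-methylpyridin-3-yl on a carbonyl carbon. Among the measured compounds shown here, no measured step covers a quinolin-4-yl group, so the aryl swaps from compound 1 are the only guide, and they stayed within the scatter. A step of a number 9 percentage points higher from compound 3 to compound 4 (within the scatter) is therefore expected for compound 4, upward but small. Compound 4 is estimated to give 25%, with a range from 10% to 42%.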

Compound 4, a percentage reported as activity, at one dose (the size of the read-out at that dose, not a potency): 16%
For compound 4 the middle estimate is 9 percentage points above the measured one, and the stated range covers the measured number.
By their numbers in this assay, from the lowest: compounds 3, 4, 1 and 2 (each within the scatter of the next, the first and the last beyond it).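

Replacing 2-methylpyridin-3-yl with the larger, two-ring quinolin-4-yl on the carbonyl carbon gave no change at the digits printed from compound 3 to compound 4 (within the scatter) in this assay, so this position accepts the added aromatic ring of carbon only without a measurable shift. The other two comparisons give a number 7 percentage points lower from compound 1 to compound 4 (within the scatter) and a number 17 percentage points lower from compound 2 to compound 4 (beyond the scatter), which places compound 4 with compound 3 in standing beyond the scatter from compound 2. The data offered here contain nothing that explains these readings.

As far as these compounds go, whether a carboxylic acid or a primary amine on the aromatic ring at this carbonyl carbon would shift the reading remains open. So does whether a methoxy group on quinolin-4-yl would bring the reading of compound 4 towards that of compound 2.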